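The source may hold more compounds than are shown below. What is called first, only, known or untested is meant among the compounds shown, and "the series" means these compounds.

Measured compounds in a functional assay on MCF7 cells (Homo sapiens) for antiproliferative activity, read by MTT assay, with a stated time of 72 h; on this read-out higher numbers stand for weaker inhibition and lower numbers for stronger inhibition:

- compound 1, `O=C1NC(=O)/C(=C/C2=Cc3ccccc3OC2)S1`: compound 1 gives 99400 nM.
- compound 2, `CN1C(=O)S/C(=C\C2=Cc3ccccc3OC2)C1=O`: for compound 2 the result is a limit of the assay, > 100000 nM.
- compound 3, `CCN1C(=O)S/C(=C\C2=Cc3ccccc3OC2)C1=O`: for compound 3 the result is likewise a limit of the assay, > 200000 nM.

Among these three, compound 1 is the only one with an actual number; the other two sit at limits, namely the limit of > 100000 nM in this assay, at which 1 of the 3 values shown sits, and (the limit of > 200000 nM in this assay, at which 1 of the 3 values shown sits). Every measured step concerns the amide-type nitrogen in the ring of the shared core: a number no lower from compound 1 to compound 2 (the limit leaves the size open), an at least 2.0-fold higher number from compound 1 to compound 3 (0.30 log units; that floor lies within the scatter) and a step that the two limits leave unreadable from compound 2 to compound 3. None of these steps can be read as a clear size, and all of them leave the aromatic ring untouched.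

Compound 4, `O=C1NC(=O)/C(=C/C2=Cc3cc(Br)ccc3OC2)S1`, departs from compound 1 in a different place: bromo in place of hydrogen on an aromatic carbon. Among the measured compounds shown here, no measured step bears on a change at the aromatic ring, so the data give no direction for it in this assay. The expected step, a 1.4-fold lower number from compound 1 to compound 4 (0.15 log units; within the scatter), is therefore taken to lie within the usual scatter, with the measured number of compound 1 as the anchor. Compound 4 is estimated at 70000 nM, within a range from 20000 nM to 200000 nM, with a fair chance that only a limit is reported.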

Compound 4, half-maximal inhibitory concentration: 57900 nM
The estimate for compound 4 lay 1.2-fold (0.08 log units) above the measured number; the measured number falls inside the stated range.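

In this assay, among the compounds shown here, this is the only readable step at the aromatic ring rather than at the amide-type nitrogen: bromo in place of hydrogen on an aromatic carbon gives a 1.7-fold lower number from compound 1 to compound 4 (0.23 log units; within the scatter). That step stays within the scatter, so compound 1 and compound 4 cannot be told apart here, and this single change at this place on the six-membered aromatic ring leaves no clear mark on the read-out, while compound 4, like compound 1, gives an actual number rather than a limit of the assay. Nothing measured here offers an explanation for the step.

The compounds shown leave open whether another group on this same aromatic carbon, such as an amine, a methoxy group or a carboxylic acid, would move the number beyond the scatter, and whether bromo on another carbon of that ring would do so. They also leave open how bromo would combine with methyl or ethyl on the amide-type nitrogen, the two changes that gave compound 2 and compound 3, both of which stand at limits of the assay.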